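Chloro for fluoro on the outer phenyl ring

This account rests on a few compounds, and the source may have more. Where it says the series, first, only, none or still open, it means among the compounds named here.

compound 1: `CN1CCN(Cc2csc(N)c2C(=O)c2ccc(Cl)cc2)CC1` gives 1.7 nM
compound 2: `Nc1scc(CN2CCN(c3ccc(F)cc3)CC2)c1C(=O)c1ccc(Cl)cc1` gives 1.8 nM

Of the compounds shown here, two have been measured in an assay on CHO cells for displacement of a labelled ligand from adenosine receptor A1 (Homo sapiens); on this read-out lower numbers stand for tighter binding and higher numbers for weaker binding. Compound 2 holds the highest of the two numbers, and its nearest neighbour is compound 1, which lies within the scatter of it; the step of a 1.1-fold higher number from compound 1 to compound 2 (0.02 log units; within the scatter) shows that replacing methyl with 4-fluorophenyl on the amine nitrogen in the ring leaves the read-out essentially unchanged.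

Compound 3 `Nc1scc(CN2CCN(c3ccc(Cl)cc3)CC2)c1C(=O)c1ccc(Cl)cc1` differs from compound 2 by chloro in place of fluoro on an aromatic carbon. Within the data shown here, no measured pair compares chloro with fluoro in this position, so the one step on record bears on it only indirectly, and that step was within the scatter. On this basis the step from compound 2 to compound 3 is expected to be no change at the digits printed from compound 2 to compound 3 (within the scatter), with no change beyond the scatter foreseen. Compound 3 is therefore estimated at 1.8 nM, with a range from 0.7 nM to 4.5 nM.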

Compound 3, dissociation constant: 1.8 nM
For compound 3 middle estimate and measured number coincide at the digits printed; low and high end bracket the measured number.
By their numbers in this assay, from the lowest: compounds 1, 2 and 3 (each within the scatter of the next).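

In this assay, among these compounds, the first direct comparison at this position, chloro in place of fluoro on an aromatic carbon para to a large group gives (no change at the digits printed from compound 2 to compound 3 (within the scatter)). Exchanging methyl for 4-chlorophenyl on the amine nitrogen in a ring gives (a 1.1-fold higher number from compound 1 to compound 3 (0.02 log units; within the scatter)), so that 4-chlorophenyl, like 4-fluorophenyl, stays within the scatter of the methyl group of compound 1. No supporting measurement is available to account for this lack of difference.

From the compounds shown here alone, whether the read-out would hold with a methoxy group, a nitrile or a carboxylic acid at this position on the phenyl ring remains open. Also open, going by these compounds, is whether a longer chain on the amine nitrogen in a ring would stay within the scatter of these three compounds.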